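A few compounds are considered here, and "the series" means these few. Any claim that something is new, unique, unknown or untested is made for them only; others in the source may bear on it.

In a functional assay on KB cells (nasopharynx, Homo sapiens) for antiproliferative activity (a higher number here means a weaker inhibitor, a lower number a stronger inhibitor), compound 1 `N#Cc1ccc(S(=O)(=O)Nc2cccc3c(Cl)c[nH]c23)cc1` gives 11 ug/mL and compound 2 `CS(=O)(=O)Nc1ccc(S(=O)(=O)Nc2cccc3c(Cl)c[nH]c23)cc1` gives 12 ug/mL with the two values within the scatter of each other. Compound 3 `CNS(=O)(=O)c1ccc(S(=O)(=O)Nc2cccc3c(Cl)c[nH]c23)cc1` has methylsulfamoyl in place of methanesulfonamido on an aromatic carbon para to a large group (methylsulfamoyl in place of methanesulfonamido on an aromatic carbon) and awaits measurement. Within the data shown here, the one measured step that bears on this, a 1.1-fold higher number from compound 1 to compound 2 (0.04 log units; within the scatter) when methanesulfonamido replaced cyano on an aromatic carbon, stayed within the scatter, so no step beyond the scatter is expected here. The expected outcome is no change at the digits printed from compound 2 to compound 3 (within the scatter) as an estimate. Compound 3 is estimated at 12 ug/mL with 5 ug/mL to 25 ug/mL as its expected range.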

Compound 3, half-maximal inhibitory concentration: 15 ug/mL
Compound 3: the middle estimate sits 1.3-fold (0.10 log units) below what was measured, and the stated range covers the measured number.
By their numbers in this assay, from the lowest: compounds 1, 2 and 3 (each within the scatter of the next).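

In this assay joining the same atoms differently, with methylsulfamoyl in place of methanesulfonamido, gave a 1.3-fold higher number from compound 2 to compound 3 (0.10 log units; within the scatter) and so added a second step at this aromatic carbon para to a large group that stays within the scatter. Methylsulfamoyl in place of cyano gave a 1.4-fold higher number from compound 1 to compound 3 (0.13 log units; within the scatter) and likewise stays within the scatter, so the three groups shown cannot be told apart here. Nothing available explains this result.

The compounds shown leave open whether an amine, a carboxylic acid or a longer chain at this position would give a step beyond the scatter. They also leave open how changes elsewhere on the shared core would read.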